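From a Chloro Group to a Benzyloxy Group

The source may report more compounds than this note shows. Statements on the series, on what has been measured and on what is new or still open speak of the compounds shown alone.

In an assay for inhibition of Tryptophan 2,3-dioxygenase (Homo sapiens), with stated times of 10 min and 60 min, tested at 100 uM (on this read-out higher numbers stand for a stronger effect at the one concentration tested and lower numbers for a weaker effect), compound 1 `O=[N+]([O-])c1ccccc1CNc1cc(C(F)(F)F)cc2[nH]ncc12` gives 95%.
In this assay compound 2 `O=[N+]([O-])c1ccc(O)cc1CNc1cc(Br)cc2[nH]ncc12` gives 99%.
In this assay compound 3 `O=[N+]([O-])c1cc(Cl)ccc1CNc1cc(C(F)(F)F)cc2[nH]ncc12` gives 93%.

All three measured compounds share the same core and sit near the top of the read-out. Compound 3 has the lowest of the three numbers, yet its gaps to compound 1 and to compound 2 are both within the scatter, so the three cannot be ranked against each other.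

Compound 4 `O=[N+]([O-])c1cc(OCc2ccccc2)ccc1CNc1cc(C(F)(F)F)cc2[nH]ncc12` differs from compound 3 in one place: benzyloxy in place of chloro on an aromatic carbon.

Going by the values given here, only one measured step touches the same aromatic carbon: a number 2 percentage points lower from compound 1 to compound 3 (within the scatter). Chloro in place of hydrogen there left the number essentially unchanged. Among the compounds with values here, no measured compound carries a benzyloxy group, so nothing shows how this larger group behaves; the expectation therefore rests on the single within-scatter step at that position and on the high, closely grouped numbers of all three measured compounds.

Compound 4 is expected to stay high in this assay, with an estimated 90%, between 72% and 99%. The expected step is a number 3 percentage points lower from compound 3 to compound 4 (within the scatter), which would lie within the scatter.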

Compound 4, a percentage reported as inhibition, at one concentration (the size of the read-out at that concentration, not a potency): 55%
Beside the measured number, compound 4's estimate is 35 percentage points above it, and the stated range ends above it.
By their numbers in this assay, from the lowest: compound 4; then compounds 3, 1 and 2 (each within the scatter of the next).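

The earlier compounds shown here showed only that chloro and hydrogen on this aromatic carbon give numbers within the scatter of each other, which left open how much the position could take. Benzyloxy settles part of that: in this assay its exchange for chloro gives a number 38 percentage points lower from compound 3 to compound 4 (beyond the scatter) and its exchange for hydrogen gives a number 40 percentage points lower from compound 1 to compound 4 (beyond the scatter) so this carbon does not accept every group without a loss. Nothing available here explains the loss.

Which part of the benzyloxy group goes with the lower number stays open: a methoxy group would keep the oxygen without the added ring, while a phenyl group would keep the ring without the oxygen. An amine or a carboxylic acid on this carbon would show how groups of other kinds fare here.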